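A few compounds are considered here, and "the series" means these few. Any claim that something is new, unique, unknown or untested is made for them only; others in the source may bear on it.

Three measured compounds share one core and differ only in the aryl group on the triple-bonded carbon. Compound 1 `COc1ccc(C#Cc2cc(Cl)cn3c([N+](=O)[O-])c(CS(=O)(=O)c4ccccc4)nc23)cc1` carries a 4-methoxyphenyl there, compound 2 `O=[N+]([O-])c1c(CS(=O)(=O)c2ccccc2)nc2c(C#Cc3ccc(F)cc3)cc(Cl)cn12` a 4-fluorophenyl, and compound 3 `O=[N+]([O-])c1c(CS(=O)(=O)c2ccccc2)nc2c(C#Cc3cccc(F)c3)cc(Cl)cn12` a 3-fluorophenyl. In an ADME assay on HepG2 cells (Homo sapiens) for cytotoxicity, read by MTT assay, with a stated time of 72 h (on this read-out higher numbers stand for lower toxicity in this test and lower numbers for higher toxicity in this test), compound 1 gives > 3900 nM, which is a limit of the assay and not a number. In this assay compound 2 also returns a limit, > 3900 nM. In this assay compound 3 likewise returns a limit, > 3900 nM. Because every value rests at the limit of > 3900 nM in this assay, at which 3 of the 3 values shown sit, the steps a step that the two limits leave unreadable from compound 1 to compound 2, a step that the two limits leave unreadable from compound 1 to compound 3 and a step that the two limits leave unreadable from compound 2 to compound 3 cannot be sized, and no order among the three compounds can be read. Compound 3 thus stands where the whole set stands, at the limit, with nothing to separate it from compound 1 or compound 2.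

Compound 4 `O=[N+]([O-])c1c(CS(=O)(=O)c2ccccc2)nc2c(C#Cc3ccccc3F)cc(Cl)cn12` differs from compound 3 by 2-fluorophenyl in place of 3-fluorophenyl on a triple-bonded carbon. Among the compounds with values here, the three unreadable steps are the only measured evidence that bears on this change, and none of them could be sized; all the aryl exchanges so far left the read-out at the limit. The step that the limit leaves unreadable from compound 3 to compound 4 is therefore expected to show no movement beyond the scatter. Compound 4 is estimated at 6000 nM, within a range from 3000 nM to 20000 nM, most likely reported again as a limit.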

Compound 4, half-maximal cytotoxic concentration: > 3900 nM
Compound 4 gave a limit, no number; the forecaster's own chance of this, stated with the estimate: 85%; the middle value does not contradict the limit.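

In this assay compound 4 gives > 3900 nM, which is a limit and not a number. Its steps from compound 1, compound 2 and compound 3 therefore cannot be read: the limit of > 3900 nM in this assay, at which 4 of the 4 values shown sit.

The compounds shown leave open whether the 2-fluorophenyl, 3-fluorophenyl, 4-fluorophenyl and 4-methoxyphenyl groups differ at all in this assay.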